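Replacing an Ethyl Amide with an Aromatic Amide

The source may hold more compounds than are shown below. What is called first, only, known or untested is meant among the compounds shown, and "the series" means these compounds.

Compound 1 `CCC(=O)Nc1ncc(-c2ccc(OC)cc2)n1C` carries an ethyl group on the carbonyl carbon of its amide. In a toxicity assay on THP-1 cells (Homo sapiens) for inhibition (a lower number here means that less compound is tolerated, a higher number that more compound is tolerated), compound 1 gives > 100000 nM, which is a limit of the assay rather than a measured number. Compound 4 `COc1ccc(-c2cnc(NC(=O)c3cccc(C)c3)n2C)cc1` differs from compound 1 in one place: 3-methylphenyl in place of ethyl on a carbonyl carbon. The closest measured pair is compound 2 `Cc1ccccc1-c1cnc(NC(=O)c2ccc(F)cc2)n1C` and compound 3 `Cc1cccc(-c2cnc(NC(=O)c3ccc(F)cc3)n2C)c1`, both of which already carry an aromatic ring on the carbonyl carbon. Compound 2 gives > 50000 nM, again a limit. Compound 3 gives > 100000 nM, also a limit. The step that the two limits leave unreadable from compound 2 to compound 3 is therefore unreadable. Because those two compounds sit at the limit of > 100000 nM in this assay, at which 2 of the 3 values shown sit, and (the limit of > 50000 nM in this assay, at which 1 of the 3 values shown sits), the expected step is a number no higher from compound 1 to compound 4 (the limit leaves the size open), nothing beyond the scatter. Compound 4 is estimated at 100000 nM, between 50000 nM and 300000 nM, most likely reported only as a limit again.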

Compound 4, half-maximal cytotoxic concentration: > 100000 nM
Compound 4: no number, only a limit; the forecaster's own chance of this, stated with the estimate: 85%; the middle value sits exactly at the limit.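

No step can be read from compound 1 to compound 4, as each gives only a limit of the assay, not a number. The compounds shown leave open whether 3-methylphenyl in place of ethyl changes the result in this assay at all.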